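The source may hold more compounds than are shown below. What is called first, only, known or untested is meant among the compounds shown, and "the series" means these compounds.

In a functional assay on A549 cells (Homo sapiens) for inhibition, read by colorimetric assay and MTT assay, with a stated time of 72 h (on this read-out higher numbers stand for weaker inhibition and lower numbers for stronger inhibition), compound 1 `C=CCCCCOc1ccc(C)cc1-c1cnc(OCCC=C)n1C` gives 59000 nM and compound 2 `CCCCCCOc1ncc(-c2ccccc2OC)n1C` gives 37000 nM. These two values lie within the usual scatter of each other, so compound 2 stands level with compound 1. Compound 3 `COc1ccccc1-c1cnc(OCCCc2ccccc2)n1C` differs from compound 2 by phenyl in place of propyl on a saturated chain carbon, three bonds along the chain from an oxygen on an aromatic ring. Going by the values given here, no measured step informs this change, so in this assay the expected step of a 1.5-fold lower number from compound 2 to compound 3 (0.17 log units; within the scatter) is small and no larger than the scatter. Compound 3 is estimated at 25000 nM, within a range of 9000 nM to 70000 nM.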

Compound 3, half-maximal inhibitory concentration: 3000 nM
Estimate against measurement, compound 3: 8.3-fold (0.92 log units) above; measured number below the stated range.
By their numbers in this assay, from the lowest: compound 3; then compounds 2 and 1 (each within the scatter of the next).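

In this assay, phenyl in place of propyl on a saturated chain carbon, three bonds along the chain from an oxygen on an aromatic ring, gives a 12-fold lower number from compound 2 to compound 3 (1.09 log units; beyond the scatter). This shows that the group at this place on the chain can strongly change the read-out, which compounds 1 and 2, level with each other, could not show. Nothing at hand explains the size of this step. On these data alone, whether a cyclohexyl group, a longer chain or a phenyl carrying an amine would match this step remains open.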